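Extending the Chain Between Core and Azepane in a Sigma Ligand

A few compounds are considered here, and "the series" means these few. Any claim that something is new, unique, unknown or untested is made for them only; others in the source may bear on it.

Measured compounds:
compound 1, `O=c1sc2ccccc2n1CCCCCCN1CCCCCC1`, 7.5 nM
compound 2, `CCC(=O)c1ccc2c(c1)sc(=O)n2CCCCCCN1CCCCCC1`, 10.4 nM
compound 3, `CCCc1ccc2c(c1)sc(=O)n2CCCCCN1CCCCCC1`, 4.6 nM

All three were tested in an assay on cell membranes for displacement of a labelled ligand from Sigma non-opioid intracellular receptor 1 (Rattus norvegicus); a higher number here means a weaker inhibitor, a lower number a stronger inhibitor. Compound 3 gives the lowest of the three numbers; compound 1 is the nearest to it, a gap that lies within the scatter, while compound 2 is the furthest, a gap that goes beyond the scatter. Within the data shown here, the one measured step with a single change, a 1.4-fold higher number from compound 1 to compound 2 (0.14 log units; within the scatter), lies within the scatter and concerns a substituent on the aromatic ring, not the chain.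

The next compound, compound 4 with structure `CCCc1ccc2c(c1)sc(=O)n2CCCCCCN1CCCCCC1`, has not been measured. Compared with compound 3 the change is (azepan-1-yl)methyl in place of azepan-1-yl on a saturated chain carbon, five bonds along the chain from an aromatic nitrogen. Among the measured compounds shown here, no measured step bears on the length of the chain between the core and the azepane; the step from compound 1 to compound 2 only shows that a change on the aromatic ring left this assay essentially unchanged. With nothing pointing either way, the expectation for this assay is a step of no more than the scatter, in no preferred direction, so the estimated step is a 1.2-fold higher number from compound 3 to compound 4 (0.08 log units; within the scatter). Compound 4 is therefore estimated at 5.5 nM, with a range from 2.5 nM to 12 nM.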

Compound 4, inhibition constant: 6.3 nM
Compound 4: middle estimate off by 1.1-fold (0.06 log units), on the low side; the range from low to high includes it.
By their numbers in this assay, from the lowest: compounds 3, 4, 1 and 2 (each within the scatter of the next, the first and the last beyond it).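

In this assay, among these compounds, (azepan-1-yl)methyl in place of azepan-1-yl on a saturated chain carbon, five bonds along the chain from an aromatic nitrogen, gives the first measured step at this position, a 1.4-fold higher number from compound 3 to compound 4 (0.14 log units; within the scatter), so with propyl on the ring this change in the chain cannot be told from repeat scatter. With the chain of compound 4 fixed, propyl in place of propanoyl gives a 1.7-fold lower number from compound 2 to compound 4 (0.22 log units; within the scatter) and propyl in place of hydrogen gives a 1.2-fold lower number from compound 1 to compound 4 (0.08 log units; within the scatter), so neither single change on that aromatic carbon separates the compounds in this assay any more than the earlier ring step did. Nothing available beyond these binding numbers bears on why the steps are this small.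

The compounds shown leave open whether a still longer chain, or a piperidine or morpholine in place of the azepane, would also stay within the scatter in this assay. They also leave open whether a group of a different kind on the aromatic carbon, such as a carboxylic acid or an amine, would give a step as small as those seen with propyl and propanoyl.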